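This account rests on a few compounds, and the source may have more. Where it says the series, first, only, none or still open, it means among the compounds named here.

Measured compounds, tested in a functional assay on MCF7 cells (Homo sapiens) for antiproliferative activity, read by MTT assay, with a stated time of 72 h; on this read-out higher numbers stand for weaker inhibition and lower numbers for stronger inhibition:
Compound 1 `C=C1CN/C(=N/c2ccccc2)S1`: > 100000 nM
Compound 2 `COc1ccc(/C=C2\S/C(=N\c3ccc(Cl)cc3)N(C)C2=O)cc1`: 39300 nM

The entry for compound 1, > 100000 nM, is a limit of this assay and not a number. Among the measured compounds shown here, compound 2, at 39300 nM, therefore holds the only true number in the set, so it can be ranked against no other exact value.

Compound 3 `COc1ccc(/C=C2\S/C(=N\c3ccccc3)N(C)C2=O)cc1` is the next analogue to be examined. It departs from compound 2 in one place: hydrogen in place of chloro on an aromatic carbon. In words, hydrogen stands in place of chloro on an aromatic carbon, para to a large group, so the 4-chlorophenyl becomes a phenyl. For the measured compounds named here, no measured pair in this small set isolates that change, so the data give no direct size for it in this assay. The expectation is therefore modest, with no shift beyond the usual scatter and no firm direction. The expected change is a 1.1-fold higher number from compound 2 to compound 3 (0.06 log units; within the scatter), an estimate anchored on compound 2 at 39300 nM. For compound 3 the estimated value is 45000 nM, with an expected range from 15000 nM to 100000 nM.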

Compound 3, half-maximal inhibitory concentration: > 100000 nM
Compound 3: no number, only a limit; the forecaster's own chance of this, stated with the estimate: 25%; middle value at least 2.2-fold (0.34 log units) from the limit.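

In this assay, putting hydrogen in place of chloro on an aromatic carbon, so that the 4-chlorophenyl becomes a phenyl, gives an at least 2.5-fold higher number from compound 2 to compound 3 (0.40 log units; beyond the scatter). Among the compounds shown here, this is the first pair in the set that differs in one place, and it shows that the chloro at this position, para to a large group, matters in this assay: with it, compound 2 gives a true number, and without it, no number can be read. The step has a lower bound but no upper bound because compound 3 holds a limit and not a number: the limit of > 100000 nM in this assay, at which 2 of the 3 values shown sit.

The compounds shown leave open whether another group at this position, such as bromo, methyl or an amine, would match the reading of compound 2, fall short of it or improve on it. For the compounds shown here, with only this one pair, they also leave open whether removing the chloro would have the same effect if the rest of the shared core were changed.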